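The source may report more compounds than this note shows. Statements on the series, on what has been measured and on what is new or still open speak of the compounds shown alone.

Measured so far:
compound 1, `COC(=O)C1=C(C)NC(c2nccs2)=NC1(C)c1ccc(S(C)(=O)=O)cc1`, with 365 ug/mL
compound 2, `COC(=O)C1=C(CN2CCCCC2)NC(c2nccs2)=NC1(C)c1ccc(F)cc1`, with 282 ug/mL

Both numbers come from a physicochemical assay for solubility, read by HPLC, in phosphate buffer, at pH 6.5; on this read-out lower numbers stand for lower solubility and higher numbers for higher solubility. Compound 2 stands at the lower of the two numbers, yet the gap to compound 1 lies within the scatter of repeated measurements of this kind, so the two compounds cannot really be told apart on this read-out.

Compound 3, `COC(=O)C1=C(Cn2ccnc2)NC(c2nccs2)=NC1(C)c1ccc(F)cc1`, has not yet been measured in this assay. It differs from compound 2 in a single place: 1H-imidazol-1-yl in place of piperidin-1-yl on a saturated chain carbon bound to a double-bonded ring carbon. Going by the values given here, no measured pair in this set shows that same change, so its effect on this read-out is not known from the data at hand; the expectation can rest only on what compound 2 gives, 282 ug/mL.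

The expected outcome is a small downward step from compound 2 to compound 3, of a size close to the edge of the usual scatter, a 1.9-fold lower number from compound 2 to compound 3 (0.27 log units; within the scatter). Compound 3 is estimated at 150 ug/mL, with a likely range from 50 ug/mL to 400 ug/mL. Whether this holds is what the measurement will show.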

Compound 3, solubility: 338 ug/mL
The estimate for compound 3 lay 2.3-fold (0.35 log units) below the measured number; the measured number falls inside the stated range.
By their numbers in this assay, from the lowest: compounds 2, 3 and 1 (each within the scatter of the next).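

In this assay, putting 1H-imidazol-1-yl in place of piperidin-1-yl on a saturated chain carbon bound to a double-bonded ring carbon gives a 1.2-fold higher number from compound 2 to compound 3 (0.08 log units; within the scatter). Going by these compounds alone, this is the first pair in the set that differs in only one place, so it gives the first direct reading of a change at this position: a six-membered non-aromatic ring and a five-membered aromatic ring with 2 hetero atoms cannot be told apart on this read-out, even though the two groups differ in ring size, aromaticity and hetero atom count. No supporting measurement bears on why the two groups read alike, so this pair records the outcome without explaining it.

This is a single pair with a single pair of ring groups, so it does not show whether other groups on the same chain carbon, such as an open-chain dimethylamino group, a morpholin-4-yl ring or a carboxylic acid, would also stay within the scatter of compound 2. It also leaves open whether the same swap would read alike on a different core, or with a different group in place of the fluorine on the shared core.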